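From Cyclohexyloxy to Butyl: Estimating Compound 4

A few compounds are considered here, and "the series" means these few. Any claim that something is new, unique, unknown or untested is made for them only; others in the source may bear on it.

Compound 1 `Fc1ccc2ncc(-c3nn[nH]n3)cc2c1`: in a functional assay on the whole organism (strain Sprague-Dawley) for inhibition, with Rattus norvegicus as the target (on this read-out lower numbers stand for an effect already at smaller amounts and higher numbers for an effect only at larger amounts of compound), compound 1 gives < 25 mg/kg, which is a limit of the assay.
Compound 2 `c1cc2ncc(-c3nn[nH]n3)cc2cc1OC1CCCCC1`: in this assay compound 2 gives 5 mg/kg.
Compound 3 `O=C(O)c1cnc2ccc(OC3CCCCC3)cc2c1`: in this assay compound 3 gives > 25 mg/kg, which is a limit of the assay.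

Within the data shown here, compound 2 therefore holds the only plain number in this assay; the other two values are limits. Compound 4 `CCCCc1ccc2ncc(-c3nn[nH]n3)cc2c1` differs from compound 2 by butyl in place of cyclohexyloxy on an aromatic carbon. Among the measured compounds shown here, no measured step covers this change: a step that the limit leaves unreadable from compound 1 to compound 2 stays unreadable because of the limit of < 25 mg/kg in this assay, at which 1 of the 3 values shown sits, and an at least 5.0-fold higher number from compound 2 to compound 3 (0.69 log units; beyond the scatter) concerns the other end of the molecule. The change is expected to give a 1.2-fold higher number from compound 2 to compound 4 (0.08 log units; within the scatter). Compound 4 is thus estimated at 6 mg/kg, within 2 mg/kg to 20 mg/kg.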

Compound 4, minimum effective dose: 5 mg/kg
The estimate for compound 4 lay 1.2-fold (0.08 log units) above the measured number; low and high end bracket the measured number.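

In this assay, this position accepts two quite different groups: butyl in place of cyclohexyloxy gives no change at the digits printed from compound 2 to compound 4 (within the scatter). Within this pair, then, a number of this size needs neither the ring nor the oxygen of cyclohexyloxy, since butyl has neither. The steps from compound 1 to compound 2 and to compound 4 cannot be read: the limit of < 25 mg/kg in this assay, at which 1 of the 4 values shown sits.

The compounds shown leave open how far this tolerance extends. An amine or a longer chain such as octyl at this position could keep the number or shift it.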